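From nitro to acetoxy on an aromatic carbon

The source may report more compounds than this note shows. Statements on the series, on what has been measured and on what is new or still open speak of the compounds shown alone.

compound 1 `O=C1C=CCC/C1=C\C=C\c1ccccc1`: 4200 nM
compound 2 `O=C1C=CCC/C1=C\C=C\c1ccc(Cl)cc1`: 3200 nM
compound 3 `O=C1C=CCC/C1=C\C=C\c1ccc([N+](=O)[O-])cc1`: 4200 nM

In a functional assay on Bel-7402 cells (Homo sapiens) for cytotoxicity, read by MTT assay, with a stated time of 72 h (a lower number here means a stronger inhibitor, a higher number a weaker inhibitor), compound 3 gives 4200 nM, level at the digits shown with compound 1, and all three values lie within the scatter of one another. The next compound is compound 4 `CC(=O)Oc1ccc(/C=C/C=C2\CCC=CC2=O)cc1`, which differs from compound 3 as follows: acetoxy in place of nitro on an aromatic carbon. This places acetoxy in place of nitro on an aromatic carbon, para to a large group. Among the measured compounds shown here, no measured compound carries acetoxy, so the evidence is indirect. It comes from the measured changes on an aromatic carbon: a 1.3-fold lower number from compound 1 to compound 2 (0.12 log units; within the scatter), no change at the digits printed from compound 1 to compound 3 (within the scatter) and a 1.3-fold higher number from compound 2 to compound 3 (0.12 log units; within the scatter). Each of these lies within the scatter, so no step beyond the scatter is expected in this assay. The estimated step is a 1.1-fold lower number from compound 3 to compound 4 (0.02 log units; within the scatter). The expected value for compound 4 is 4000 nM, with an estimated range of 2000 nM to 8000 nM.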

Compound 4, half-maximal inhibitory concentration: 3800 nM
Estimate against measurement, compound 4: 1.1-fold (0.02 log units) above; the measured number falls inside the stated range.
By their numbers in this assay, from the lowest: compounds 2, 4, 1 and 3 (each within the scatter of the next).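

In this assay, acetoxy in place of nitro gives a 1.1-fold lower number from compound 3 to compound 4 (0.04 log units; within the scatter) and thus stays within the scatter, as do acetoxy in place of chloro, with a 1.2-fold higher number from compound 2 to compound 4 (0.07 log units; within the scatter) as its step, and acetoxy in place of hydrogen, with a 1.1-fold lower number from compound 1 to compound 4 (0.04 log units; within the scatter) as its step. On this aromatic carbon, para to a large group, the larger acetoxy therefore joins hydrogen, chloro and nitro, and all four compounds lie within the scatter of one another. No measured property is available to account for this result.

As far as these compounds go, it remains open whether an amine, a carboxylic acid or a longer chain on this same carbon would also stay within the scatter. The compounds shown also leave open whether any group at another place on the aromatic ring would give a step beyond it.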